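The source may hold more compounds than are shown below. What is called first, only, known or untested is meant among the compounds shown, and "the series" means these compounds.

Among the measured compounds shown here, in a functional assay on HCT-116 cells (Homo sapiens) for antiproliferative activity (a lower number here means a stronger inhibitor, a higher number a weaker inhibitor), three related compounds have numbers so far. Compound 1 `Cc1c2c(n3c1CCCNC[C@H](C)Nc1cc-3ccc1C(N)=O)CC(C)(C)CC2=O` gives 93 nM and compound 3 `COCCC(=O)N1CCCc2c(C)c3c(n2-c2ccc(C(N)=O)c(c2)N[C@@H](C)[C@@H]1C)CC(C)(C)CC3=O` gives 55 nM in this measurement. Compound 2 `CC(=O)N1CCc2c(C)c3c(n2-c2ccc(C(N)=O)c(c2)N[C@@H](C)[C@H](C)C1)CC(C)(C)CC3=O` reads 24 nM and holds the lowest number of the three, beyond the scatter from each of the other two.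

Compound 4 `CC[C@H](N)C(=O)N1CCc2c(C)c3c(n2-c2ccc(C(N)=O)c(c2)N[C@@H](C)[C@H](C)C1)CC(C)(C)CC3=O` departs from compound 2 by a single change (1-aminopropyl in place of methyl on a carbonyl carbon) with 1-aminopropyl in place of methyl on a carbonyl carbon. For the measured compounds named here, no measured pair isolates a change at this place, so the evidence is indirect. Compound 3 also carries a longer chain on a carbonyl carbon and gives 55 nM while differing from compound 2 elsewhere too, so only a modest upward step is expected in this assay here, possibly none beyond the scatter. The estimated move (a 1.3-fold higher number from compound 2 to compound 4 (0.10 log units; within the scatter)) stays small and goes toward a higher number. For compound 4 the expected value is 30 nM with an estimated range from 10 nM to 90 nM as the working window.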

Compound 4, half-maximal inhibitory concentration: 33 nM
For compound 4 the middle estimate is 1.1-fold (0.04 log units) below the measured one; the range from low to high includes it.
By their numbers in this assay, from the lowest: compounds 2, 4, 3 and 1 (each within the scatter of the next, the first and the last beyond it).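

In this assay, among the compounds shown here, the first matched pair at this place gives a 1.4-fold higher number from compound 2 to compound 4 (0.14 log units; within the scatter) for 1-aminopropyl in place of methyl on a carbonyl carbon. The amide-type nitrogen in the ring can therefore carry this larger acyl group, with its amine and defined stereocentre, without a change beyond the scatter, which compound 3 could not show as it differs from compound 2 elsewhere too. No measured evidence explains this result.

The compounds shown do not separate the contribution of the amine from that of the propyl chain, nor show how the opposite configuration at the new stereocentre would read. On these data alone, a longer chain, a carboxylic acid in place of the amine, or a cyclic amine on this carbonyl carbon also remains open.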